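The source may hold more compounds than are shown below. What is called first, only, known or untested is meant among the compounds shown, and "the series" means these compounds.

Working notes on the series. In a functional assay on COLO 205 cells (Homo sapiens) for inhibition, read by sulforhodamine B assay, with a stated time of 48 h (a higher number here means a weaker inhibitor of growth, a lower number a stronger inhibitor of growth), compound 1 `COc1ccc(-c2cc(/C=C/C(=O)c3cc(OC)c(OC)c(OC)c3)[nH]n2)cc1OC` gives 3570 nM. Compound 2 `COc1ccc(C(=O)/C=C/c2cc(-c3cc(OC)c(OC)c(OC)c3)n[nH]2)cc1` gives 3240 nM in this assay. Compound 3 `COc1ccc(C(=O)/C=C/c2cc(-c3cc(OC)c(OC)c(OC)c3)n[nH]2)cc1OC` gives 3210 nM in this assay. Going by the values given here, the one single-point step between measured compounds, a 1.0-fold lower number from compound 2 to compound 3 (0.00 log units; within the scatter), is flat. Compound 3 carries the lowest of the three numbers shown, but compound 2 and compound 1 both sit within the scatter of it, so no ranking among the three can be drawn from these figures.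

Compound 4 `COc1cc(C(=O)/C=C/c2cc(-c3cc(OC)c(OC)c(OC)c3)n[nH]2)cc(OC)c1OC` is the next step from compound 3: methoxy in place of hydrogen on an aromatic carbon. The step that bears on it is a 1.0-fold lower number from compound 2 to compound 3 (0.00 log units; within the scatter), where the same kind of replacement, a methoxy in place of hydrogen on an aromatic carbon, left the number in this assay unchanged. Compound 1, with a different arrangement of the same groups about the shared core, gives 3570 nM, again inside the same band. Among the compounds with values here, with the three measured values clustered and the one comparable step flat, the expected step of a 1.0-fold lower number from compound 3 to compound 4 (0.00 log units; within the scatter) is none beyond the scatter. The estimated value for compound 4 in this assay is 3200 nM, with a range of 1600 nM to 6400 nM.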

Compound 4, concentration for total growth inhibition: 3130 nM
Beside the measured number, compound 4's estimate is 1.0-fold (0.01 log units) above it, and the stated range covers the measured number.
By their numbers in this assay, from the lowest: compounds 4, 3, 2 and 1 (each within the scatter of the next).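

In this assay, methoxy in place of hydrogen on an aromatic carbon, at a position ortho to a methoxy group and meta to a large group, gives a 1.0-fold lower number from compound 3 to compound 4 (0.01 log units; within the scatter), so the flat result is no longer a single reading on this ring. The same replacement, read on a second core, gives a 1.1-fold lower number from compound 1 to compound 4 (0.06 log units; within the scatter), again without a shift that can be told from the scatter. The replacement therefore reads as flat on both cores shown, and the two steps agree with each other: the same change on two cores in this assay, a 1.0-fold lower number (0.00 log units; within the scatter) from compound 2 to compound 3 and a 1.1-fold lower number (0.06 log units; within the scatter) from compound 1 to compound 4, 1.1-fold (0.05 log units) apart, within the scatter of two such steps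

Only methoxy and hydrogen are shown at this position, so whether an amine, a carboxylic acid or a longer alkoxy chain there would move the number beyond the scatter stays open. Each of the four numbers lies within the scatter of the next, so no step shown yet marks a part of the structure on which the number in this assay depends.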